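Nitrile to hydroxyl at the chain end: compound 3

The source may hold more compounds than are shown below. What is called first, only, known or untested is meant among the compounds shown, and "the series" means these compounds.

Compound 1 `CCc1cc(C(C)=O)c(O)cc1OCCCCC#N` and compound 2 `C=CCc1cc(C(C)=O)c(O)cc1OCCCCCC#N` share one core and differ both in the ring alkyl group and in the ether chain, so their two values are compared only as they stand. In an assay on isolated protein for inhibition of leukotriene B4 receptor 1 (Homo sapiens), tested at 10 uM (a lower number here means less inhibition, a higher number more inhibition at the concentration tested (going by the name of the read-out)), compound 1 gives 92%, and in this assay compound 2 gives 81%. Among the compounds with values here, compound 2 is therefore the lower of the two numbers, with compound 1 as its only neighbour, higher by a margin beyond the scatter.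

Compound 3 `C=CCc1cc(C(C)=O)c(O)cc1OCCCCO` remains unmeasured. Against compound 2 it carries hydroxy in place of cyanomethyl on a saturated chain carbon, four bonds along the chain from an oxygen on an aromatic ring. Within the data shown here, no measured pair isolates this change, and the two values shown give no direct guide to it. The step from compound 2 to compound 3 in this assay is expected to be a moderate fall, a number 16 percentage points lower from compound 2 to compound 3 (beyond the scatter), though a result within the scatter is not excluded. Compound 3 is accordingly estimated at 65%, with a range from 35% to 90%.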

Compound 3, a percentage reported as inhibition, at one concentration (the size of the read-out at that concentration, not a potency): 48%
The estimate for compound 3 lay 17 percentage points above the measured number; measured number inside the range.
By their numbers in this assay, from the lowest: compound 3; then compound 2; then compound 1.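

In this assay, within the data shown here, hydroxy in place of cyanomethyl on a saturated chain carbon, four bonds along the chain from an oxygen on an aromatic ring, gives a number 33 percentage points lower from compound 2 to compound 3 (beyond the scatter) and is the first step that isolates a single change. The chain end therefore matters to this read-out: with the rest of the structure held constant, the nitrile-ended chain of compound 2 retains more inhibition at the concentration tested than the hydroxy-ended chain of compound 3. Nothing available explains the size of this step.

This single pair cannot separate the loss of the nitrile from the shortening of the chain. Still open, going by these compounds, is how a carboxylic acid or an amine at the same chain end would read, and whether a hydroxy group on a longer chain would stand closer to compound 2.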